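The source may report more compounds than this note shows. Statements on the series, on what has been measured and on what is new or still open speak of the compounds shown alone.

Two compounds of the series have numbers in a functional assay on Malme-3M cells (Homo sapiens) for inhibition, read by sulforhodamine B assay, with a stated time of 48 h; on this read-out lower numbers stand for stronger inhibition of growth and higher numbers for weaker inhibition of growth. Compound 1 `COc1cc(-c2nn(-c3cccc(NC(=O)Nc4ccc(Cl)c(Cl)c4)c3)cc2-c2ccncc2)ccc1Cl` gives 926 nM in this assay. Among the measured compounds shown here, compound 2 `COc1cc(-c2nn(-c3cccc(NC(=O)c4ccc(Cl)c(C(F)(F)F)c4)c3)cc2-c2ccncc2)ccc1Cl` gives 1180 nM in this assay; this is the highest of the two numbers, and its only neighbour is compound 1, with a 1.3-fold higher number from compound 1 to compound 2 (0.11 log units; within the scatter) lying within the scatter. Compound 3 `COc1cc(-c2nn(-c3cccc(NC(=O)Nc4ccc(Cl)c(C(F)(F)F)c4)c3)cc2-c2ccncc2)ccc1Cl` is not yet measured. It differs from compound 2 at the carbonyl carbon whose other neighbour is an amide-type nitrogen: (4-chloro-3-(trifluoromethyl)phenyl)amino in place of 4-chloro-3-(trifluoromethyl)phenyl on a carbonyl carbon. For the measured compounds named here, the single measured step bears on this only in part: a 1.3-fold higher number from compound 1 to compound 2 (0.11 log units; within the scatter) exchanged both the aryl group and the amino link in one move and stayed within the scatter, so together those two changes did not move the number beyond the scatter. Compound 3 keeps the aryl group of compound 2 and carries the amino link as compound 1 does. On that basis a step of no more than the usual scatter is expected, as a 1.2-fold lower number from compound 2 to compound 3 (0.09 log units; within the scatter). Compound 3 is estimated at 950 nM in this assay. The expected range for compound 3 runs from 400 nM to 2300 nM.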

Compound 3, concentration for 50% growth inhibition: 838 nM
Compound 3: the middle estimate sits 1.1-fold (0.05 log units) above what was measured; low and high end bracket the measured number.
By their numbers in this assay, from the lowest: compounds 3, 1 and 2 (each within the scatter of the next).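

Read alone, (4-chloro-3-(trifluoromethyl)phenyl)amino in place of 4-chloro-3-(trifluoromethyl)phenyl on a carbonyl carbon gives a 1.4-fold lower number from compound 2 to compound 3 (0.15 log units; within the scatter) in this assay, so with the aryl group held fixed, the added amino link and its hydrogen-bond donor leave the number within the scatter. The aryl change can now also be read alone: trifluoromethyl in place of chloro on an aromatic carbon gives a 1.1-fold lower number from compound 1 to compound 3 (0.04 log units; within the scatter) with the amino link held fixed, so the two parts of the earlier combined exchange each stay within the scatter when taken singly. Nothing at hand explains why these three numbers stay so close together.

Still open, from the compounds shown here alone, is whether this tolerance extends to other links on the carbonyl carbon, such as an oxygen in place of the amino nitrogen or a methylene group, or to an aryl group carrying a carboxylic acid or a dimethylamino group in place of the chloro. All three compounds also share the core of compound 1 and a single read-out, so the effect of a change in that core and the behaviour of the series in any other setting remain undefined.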